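Swapping the amide end of compound 1 for an oxolane

A few compounds are considered here, and "the series" means these few. Any claim that something is new, unique, unknown or untested is made for them only; others in the source may bear on it.

Within the data shown here, compound 1 `CCN(CC)S(=O)(=O)c1ccc(S(=O)(=O)N2CCC[C@@H](C(=O)N3CCC(O)CC3)C2)cc1` is the weakest of the three compounds measured so far: in a functional assay on MIA PaCa-2 cells (Homo sapiens) for inhibition, read by MTT assay, with a stated time of 7 days (a lower number here means a stronger inhibitor, a higher number a weaker inhibitor), compound 1 gives 870 nM. Compound 2 `CCC(CC)S(=O)(=O)c1ccc(S(=O)(=O)N2CCC[C@@H](C(=O)N3CCC(F)(F)CC3)C2)cc1` gives 13 nM in this assay, and compound 3 `CCN(CC)C(=O)c1ccc(S(=O)(=O)N2CCC[C@@H](C(=O)N3CCC(F)(F)CC3)C2)cc1` gives 70 nM. Among the measured compounds shown here, the single step that links two compounds in one place, a 5.4-fold higher number from compound 2 to compound 3 (0.73 log units; beyond the scatter), concerns the group on the aromatic carbon and leaves the amide end of the shared core untouched. Compound 4 `CCN(CC)S(=O)(=O)c1ccc(S(=O)(=O)N2CCC[C@@H](C(=O)N[C@@H]3CCOC3)C2)cc1` keeps the diethylsulfamoyl group of compound 1 and changes only that amide end: (oxolan-3-yl)amino in place of 4-hydroxypiperidin-1-yl on a carbonyl carbon. For the measured compounds named here, no measured pair shows this change, nor any change at the same place, on its own; compound 1 and compound 2 differ in two places at once, so their values say nothing separate about the amide end. The expectation for compound 4 therefore rests on compound 1 alone, and a step of a 1.4-fold higher number from compound 1 to compound 4 (0.14 log units; within the scatter) in this assay is estimated, with no direction supported beyond the scatter. Compound 4 is accordingly expected to give about 1200 nM in this assay, within a range of 300 nM to 5000 nM.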

Compound 4, half-maximal inhibitory concentration: 750 nM
Estimate against measurement, compound 4: 1.6-fold (0.20 log units) above, within the range that was stated.
By their numbers in this assay, from the lowest: compound 2; then compound 3; then compounds 4 and 1 (each within the scatter of the next).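

In this assay, among these compounds, the first measured change at the amide end of the shared core gives a 1.2-fold lower number from compound 1 to compound 4 (0.06 log units; within the scatter) and so leaves (oxolan-3-yl)amino and 4-hydroxypiperidin-1-yl indistinguishable on a carbonyl carbon, with the diethylsulfamoyl group in place. This change replaces a six-membered non-aromatic ring with a five-membered one and brings in a defined stereocentre, yet the result lies within the scatter. Nothing available explains this result.

As far as these compounds go, what the amide end of compound 2 and compound 3 contributes on its own remains open, since neither compound differs from compound 1 or compound 4 in that place alone. Also open, from the compounds shown here alone, is how this position would respond to a morpholin-4-yl group, an open-chain dimethylamino group or a group carrying a carboxylic acid on the same carbonyl carbon.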